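Nitro for amino in two related cores at the alpha4/beta2 receptor

The compounds below may be only part of what the source reports. "The series", "measured", "known", "first", "only" and "open" are said of these compounds alone.

Compound 1 `CN1CCC[C@H]1[C@H]1COc2ccc(N)cc2O1`: 140 nM
Compound 2 `CN1CCC[C@H]1[C@@H]1COc2cc(N)ccc2O1`: 86000 nM
Compound 3 `CN1CCC[C@H]1[C@H]1COc2ccc([N+](=O)[O-])cc2O1`: 33000 nM

Of the compounds shown here, three have been tested in an assay on membranes from Cerebral cortex for displacement of a labelled ligand from Neuronal acetylcholine receptor; alpha4/beta2 (Rattus norvegicus), with a stated time of 5 min; a lower number here means a stronger inhibitor, a higher number a weaker inhibitor. Compound 1 gives 140 nM, while compound 2 gives 86000 nM; the two are built from the same atoms joined differently, and the difference between the two cores is not broken down here. Compound 3 carries nitro in place of amino on an aromatic carbon and gives 33000 nM, a step of a 240-fold higher number from compound 1 to compound 3 (2.37 log units; beyond the scatter).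

Compound 4 `CN1CCC[C@H]1[C@@H]1COc2cc([N+](=O)[O-])ccc2O1` is not yet measured. It stands to compound 2 as compound 3 stands to compound 1, carrying (nitro in place of amino on an aromatic carbon), the same change at the same place. Compound 2 already gives the highest number of the three, so the room for a further rise in this assay is limited by what the assay can report. A smaller apparent step is therefore expected, a 3.5-fold higher number from compound 2 to compound 4 (0.54 log units; beyond the scatter), resting on the large step of a 240-fold higher number from compound 1 to compound 3 (2.37 log units; beyond the scatter) and on the weak starting point of compound 2 at 86000 nM. Compound 4 is estimated at 300000 nM, between 80000 nM and 3000000 nM, with a fair chance that only a limit is reported.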

Compound 4, inhibition constant: 46000 nM
Compound 4: middle estimate off by 6.5-fold (0.81 log units), on the high side; the whole stated range lies above it.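

In this assay, nitro in place of amino on an aromatic carbon gives no readable difference on the core of compound 2, a 1.9-fold lower number from compound 2 to compound 4 (0.27 log units; within the scatter). The large step seen on the core of compound 1 therefore does not carry over to the core of compound 2, and the effect of this change depends on the core in these two pairs: the same change on two cores in this assay, a 240-fold higher number (2.37 log units; beyond the scatter) from compound 1 to compound 3 and a 1.9-fold lower number (0.27 log units; within the scatter) from compound 2 to compound 4, 440-fold (2.64 log units) apart, beyond the scatter of two such steps

This does not show which feature of the two cores separates the steps, and two pairs give no rule for a third core, while compound 2 starts from 86000 nM, so its pair says little about how the change would read on a core with a lower starting number.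

The compounds shown leave open whether other groups on that aromatic carbon, such as a methoxy group, a nitrile or an acetamide, would read like amino or like nitro on either core. Going by these compounds, it also remains open whether a plain hydrogen there would match compound 2 or compound 4.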